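This account rests on a few compounds, and the source may have more. Where it says the series, first, only, none or still open, it means among the compounds named here.

Compound 1 `CC(=O)N1CCN(c2ccc([C@H]3CN(Cc4c(C)cccc4F)C[C@@H]3N(C)C)cc2)CC1`: 2830 mL/min/kg
Compound 2 `Cc1cccc(F)c1CN1C[C@H](c2ccc(C3=CCN(C(=O)CS(C)(=O)=O)CC3)nc2)[C@@H](N(C)C)C1`: 4470 mL/min/kg
Compound 3 `CN(C)[C@H]1CN(C2CCc3cccc(F)c32)C[C@@H]1C1CCN(c2ccc(C(N)=O)cn2)CC1`: 2000 mL/min/kg

Of the compounds shown here, three have so far been measured in an ADME assay on microsomes from liver (Mus musculus) for metabolic stability, read by LC-MS, tested at 0.5 uM; on this read-out higher numbers stand for fast clearance and lower numbers for slow clearance. Compound 1 stands second highest of the three numbers. Its nearest neighbour is compound 3, and the gap between the two lies within the scatter of repeated measurements; the furthest is compound 2, and that gap also lies within the scatter. Taken together, the three numbers do not separate from one another.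

Compound 4 `Cc1cccc(F)c1CN1C[C@H](c2ccc(-c3cnn(CC(N)=O)c3)cc2)[C@@H](N(C)C)C1` has not yet been measured in this assay. It differs from compound 1 in one place:

1-(carbamoylmethyl)-1H-pyrazol-4-yl in place of 4-acetylpiperazin-1-yl on an aromatic carbon

Among the measured compounds shown here, no pair of measured compounds differing in a single place is available, so nothing yet shows how a change of this kind moves the clearance in this assay. What the three measured numbers do show is a narrow band, with compound 1 near its middle. On that basis the expected step from compound 1 to compound 4 is one that stays within the scatter, with no direction to it: a 1.0-fold lower number from compound 1 to compound 4 (0.00 log units; within the scatter) is the expected outcome. Compound 4 is estimated at 2800 mL/min/kg in this assay, with a range from 1400 mL/min/kg to 5600 mL/min/kg.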

Compound 4, clearance: 3750 mL/min/kg
Compound 4: middle estimate off by 1.3-fold (0.13 log units), on the low side, within the range that was stated.
By their numbers in this assay, from the lowest: compounds 3, 1, 4 and 2 (each within the scatter of the next, the first and the last beyond it).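

In this assay, among the compounds shown here, there is now a first step between two compounds that differ in only one place: putting 1-(carbamoylmethyl)-1H-pyrazol-4-yl in place of 4-acetylpiperazin-1-yl on an aromatic carbon, para to a large group, gives a 1.3-fold higher number from compound 1 to compound 4 (0.12 log units; within the scatter). The exchange is a real one in structure, with a six-membered non-aromatic ring giving way to a five-membered aromatic ring and one hydrogen-bond donor entering, yet the size of the group stays at the same count of heavy atoms and the read-out does not separate the two compounds. No measurement at hand bears on what lies behind this result.

Going by these compounds, a single step says little about the range of this position, so it remains open whether a carboxylic acid or a primary amine on this aromatic carbon would give a step beyond the scatter. On these data alone, it is also open whether the same exchange would give a similar step in compounds built like compound 2 or compound 3, which differ from compound 1 in more than one place.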